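Replacing Piperidin-1-yl with Dimethylamino on the Side Chain

The compounds below may be only part of what the source reports. "The series", "measured", "known", "first", "only" and "open" are said of these compounds alone.

For the measured compounds named here, the series is built on a shared core, and the three measured members differ in what hangs from one saturated ring carbon. Compound 1 `Cn1ncc(Cl)c1-c1cc(C(=O)NC2CNCCC2c2ccc(C(F)(F)F)cc2)oc1Cl`, which carries no substituent there, gives 7.2 nM in an assay for inhibition of RAC-alpha serine/threonine-protein kinase (Homo sapiens), read by HTRF, with a stated time of 1 h; on this read-out lower numbers stand for stronger inhibition and higher numbers for weaker inhibition. Compound 2 `Cn1ncc(Cl)c1-c1cc(C(=O)N[C@@H]2CN[C@H](CC(O)CO)C[C@H]2c2ccc(Cl)c(Cl)c2)oc1Cl` gives 3.79 nM in this assay, and compound 3 `Cn1ncc(Cl)c1-c1cc(C(=O)N[C@@H]2CN[C@H](CCN3CCCCC3)C[C@H]2c2ccc(Cl)c(Cl)c2)oc1Cl` gives 5.65 nM. Compound 3 thus sits second highest among the three numbers, with compound 1 nearest and compound 2 furthest, and both of those gaps lie within the usual scatter. Going by the values given here, the only single-point step among the measured compounds is a 1.5-fold higher number from compound 2 to compound 3 (0.17 log units; within the scatter), which also stayed within the scatter.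

Compound 4 `CN(C)CC[C@@H]1C[C@@H](c2ccc(Cl)c(Cl)c2)[C@H](NC(=O)c2cc(-c3c(Cl)cnn3C)c(Cl)o2)CN1` is obtained by dimethylamino in place of piperidin-1-yl on a saturated chain carbon, two bonds along the chain from a saturated ring carbon. Among the compounds with values here, no measured step swaps one amine for another in this way, so the closest guide is the step at the same chain position, a 1.5-fold higher number from compound 2 to compound 3 (0.17 log units; within the scatter), which exchanged a whole side group without moving the number beyond the scatter. On that basis the step from compound 3 to compound 4 is expected to be a 1.0-fold lower number from compound 3 to compound 4 (0.01 log units; within the scatter), with no clear direction. The estimate for compound 4 in this assay is 5.5 nM, expected to fall between 2.5 nM and 12 nM.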

Compound 4, half-maximal inhibitory concentration: 3.4 nM
For compound 4 the middle estimate is 1.6-fold (0.21 log units) above the measured one; the measured number falls inside the stated range.
By their numbers in this assay, from the lowest: compounds 4, 2, 3 and 1 (each within the scatter of the next, the first and the last beyond it).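

In this assay there is a 1.7-fold lower number from compound 3 to compound 4 (0.22 log units; within the scatter) when dimethylamino takes the place of piperidin-1-yl, so on a saturated chain carbon, two bonds along the chain from a saturated ring carbon, the one six-membered non-aromatic ring can give way to a group with no ring while the number stays within the scatter. The comparison with the other side chain reads the same way, with a 1.1-fold lower number from compound 2 to compound 4 (0.05 log units; within the scatter) on going from 1,2-dihydroxyethyl to (dimethylamino)methyl on a saturated chain carbon bound to a saturated ring carbon, so these three side chains cannot be told apart in this read-out. No accompanying measurement bears on either step, and the numbers alone offer no explanation for them.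

On these data alone, whether a primary amine, a morpholine ring or a carboxylic acid in place of dimethylamino, or a longer chain carrying the same dimethylamino group, would move the number beyond the scatter remains open. Compound 1 differs from the others in more than one place, so what the side chain itself contributes also stays unresolved.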